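Trimming a methyl from the side chain of compound 1

This account rests on a few compounds, and the source may have more. Where it says the series, first, only, none or still open, it means among the compounds named here.

Going by the values given here, in a functional assay on MCF7 cells (Homo sapiens) for cytotoxicity, read by MTT assay (on this read-out lower numbers stand for stronger inhibition and higher numbers for weaker inhibition), compound 1 `CCOC(=O)C(C)Oc1c(-c2ccc(OC)cc2)oc2c(CC=C(C)C)c(O)cc(O)c2c1=O` gives 4700 nM, the only true number available in this small set. Compound 2 `CCOC(=O)C(C)Oc1cc(O)c2c(=O)c(O)c(-c3ccc(OC)cc3)oc2c1CC=C(C)C` reaches only a limit in this assay, > 100000 nM. Among the compounds with values here, compound 1 therefore stands alone as the one compound with a measured potency, and it is the natural reference point for what follows.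

Compound 3 `CCOC(=O)COc1c(-c2ccc(OC)cc2)oc2c(CC=C(C)C)c(O)cc(O)c2c1=O` keeps the core of compound 1 and alters it in one place, (hydrogen in place of methyl on a saturated chain carbon bound to a carbonyl carbon and an oxygen on an aromatic ring). This puts hydrogen in place of methyl on a saturated chain carbon bound to a carbonyl carbon and an oxygen on an aromatic ring, so that 1-(ethoxycarbonyl)ethoxy becomes (ethoxycarbonyl)methoxy. Within the data shown here, no measured pair in the set shows this change or any other single change, so its size must be judged without precedent. For so small an edit, no step beyond the usual scatter is expected in this assay. The expectation rests on compound 1 at 4700 nM. The expected change is a 1.3-fold higher number from compound 1 to compound 3 (0.11 log units; within the scatter), which stays small. Compound 3 is estimated at 6000 nM, with an expected range of 2000 nM to 20000 nM.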

Compound 3, half-maximal inhibitory concentration: > 100000 nM
Compound 3 ended at the assay's limit (the forecaster's own chance of this, stated with the estimate: 8%); at least 16-fold (1.22 log units) between middle value and limit.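

Trimming this one methyl was not a neutral edit: in this assay the change from 1-(ethoxycarbonyl)ethoxy to (ethoxycarbonyl)methoxy amounts to an at least 21-fold higher number from compound 1 to compound 3 (1.32 log units; beyond the scatter) on the shared core. Going by these compounds alone, the earlier compounds offered no pair differing in one place, so this is the first sign that the saturated chain carbon bound to a carbonyl carbon and an oxygen on an aromatic ring tolerates little change, and here a single carbon separates the one measured potency in the set from a limit. From the compounds shown here alone, compound 3 gives > 100000 nM, which is a limit of the assay and not a number, so the full size of the step stays unknown, and that limit is shared within this small set: the limit of > 100000 nM in this assay, at which 2 of the 3 values shown sit.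

What the compounds shown leave open is whether the methyl itself matters or whether any substituent at this carbon would hold the activity, such as an ethyl or a second methyl. They also leave open how the ester end of the side chain contributes, for instance whether a carboxylic acid or an amide in place of the ethyl ester would keep the potency of compound 1.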